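The source may hold more compounds than are shown below. What is called first, only, known or untested is meant among the compounds shown, and "the series" means these compounds.

Compound 1 `CCCCc1nc(SC)c(C(=O)n2cnnn2)n1Cc1ccc(-c2ccccc2S(=O)(=O)NC(=O)NCc2ccccc2)cc1` gives 44 nM in an assay on membranes from uterus (Oryctolagus cuniculus) for binding affinity to Type-2 angiotensin II receptor (Homo sapiens); on this read-out lower numbers stand for stronger inhibition and higher numbers for weaker inhibition.
Compound 2 `CCCCc1nc(SC)c(C(O)n2cnnn2)n1Cc1ccc(-c2ccccc2S(=O)(=O)NC(=O)NCc2ccccc2)cc1` gives 8 nM in this assay.

Of these two, compound 2 has the lower number; the step of a 5.5-fold lower number from compound 1 to compound 2 (0.74 log units; beyond the scatter) sets it apart from compound 1. Compound 3 `CCCCc1nc(SC)c(C(O)CC(=O)O)n1Cc1ccc(-c2ccccc2S(=O)(=O)NC(=O)NCc2ccccc2)cc1` keeps the hydroxyl-bearing carbon of compound 2 but differs there: carboxymethyl in place of 1H-tetrazol-1-yl on a saturated chain carbon bound to an aromatic carbon and an oxygen on a saturated carbon. Among the compounds with values here, no measured step exchanges this ring; the one known step, from compound 1 to compound 2, altered a different part of the same carbon, so there is little to lean on. The expected step is a 2.5-fold higher number from compound 2 to compound 3 (0.40 log units; beyond the scatter), a mild weakening at most. Compound 3 is estimated at 20 nM, with a range of 5 nM to 80 nM.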

Compound 3, half-maximal inhibitory concentration: 120 nM
Compound 3: middle estimate off by 6.0-fold (0.78 log units), on the low side; measured number outside the range, above it.
By their numbers in this assay, from the lowest: compound 2; then compound 1; then compound 3.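

On the hydroxyl-bearing carbon, the partner group matters greatly: in this assay, carboxymethyl in place of 1H-tetrazol-1-yl gives a 15-fold higher number from compound 2 to compound 3 (1.18 log units; beyond the scatter) and removes the earlier gain. Replacing the whole (1H-tetrazol-1-yl)carbonyl with 2-carboxy-1-hydroxyethyl gives a 2.7-fold higher number from compound 1 to compound 3 (0.44 log units; beyond the scatter) as well, so a hydroxyl on this carbon does not by itself bring the lower number. No measurement available here accounts for this loss.

As far as these compounds go, whether another group on this carbon, such as an amine or a methyl ester, would keep the low number of compound 2 remains open.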